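Swapping the amide's aryl group: from fluorophenyl to cyanophenyl

The compounds below may be only part of what the source reports. "The series", "measured", "known", "first", "only" and "open" are said of these compounds alone.

Of the compounds shown here, three sharing one core have been measured in a functional assay on Ramos cells (Homo sapiens) for antiproliferative activity, read by CCK-8 assay, with a stated time of 72 h, tested at 40 uM; a higher number here means more inhibition at the concentration tested (going by the name of the read-out), a lower number less inhibition. Compound 1 `CCOC(=O)c1sc(-c2cccc(NC(=O)c3ccc(C(F)(F)F)cc3)c2)nc1Nc1ccc(N2CCN(C)CC2)cc1` gives 18.4%. Compound 2 `CCOC(=O)c1sc(-c2cccc(NC(=O)c3ccccc3)c2)nc1Nc1ccc(N2CCN(C)CC2)cc1` gives 77.1%, and compound 3 `CCOC(=O)c1sc(-c2cccc(NC(=O)c3ccccc3F)c2)nc1Nc1ccc(N2CCN(C)CC2)cc1` gives 96.4%. Compound 3 thus stands highest of the three, above compound 2 by a step beyond the scatter and far above compound 1.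

Compound 4 `CCOC(=O)c1sc(-c2cccc(NC(=O)c3ccc(C#N)cc3)c2)nc1Nc1ccc(N2CCN(C)CC2)cc1` has not yet been measured. It differs from compound 3 by 4-cyanophenyl in place of 2-fluorophenyl on a carbonyl carbon. The most telling earlier step is a number 78 percentage points higher from compound 1 to compound 3 (beyond the scatter), where removing a 4-(trifluoromethyl)phenyl in favour of the 2-fluorophenyl lifted inhibition strongly; the step of a number 58.7 percentage points higher from compound 1 to compound 2 (beyond the scatter) points the same way, and a number 19.3 percentage points higher from compound 2 to compound 3 (beyond the scatter) was only modest. Compound 4 again carries a group on the same ring position type as compound 1, though a different one, so a sizeable fall is expected: a number 56.4 percentage points lower from compound 3 to compound 4 (beyond the scatter). Compound 4 is therefore estimated at 40%, with a range from 10% to 80%.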

Compound 4, a percentage reported as inhibition, at one concentration (the size of the read-out at that concentration, not a potency): 97.5%
The estimate for compound 4 lay 57.5 percentage points below the measured number; measured number above the stated range.
By their numbers in this assay, from the lowest: compound 1; then compound 2; then compounds 3 and 4 (each within the scatter of the next).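

Compound 1 left open whether any group on this aryl ring lowers inhibition, and the 4-cyanophenyl amide shows that it does not: adding cyano gives a number 20.4 percentage points higher from compound 2 to compound 4 (beyond the scatter), whereas trifluoromethyl had pulled the number down. Exchanging only trifluoromethyl for cyano gives a number 79.1 percentage points higher from compound 1 to compound 4 (beyond the scatter), so at this place the identity of the group matters, not merely the presence of one. Replacing 2-fluorophenyl with 4-cyanophenyl gives a number 1.1 percentage points higher from compound 3 to compound 4 (within the scatter), so these two differently substituted rings cannot be told apart at this single concentration.

No measurement shown here explains the difference between cyano and trifluoromethyl. From the compounds shown here alone, it also remains open whether a methoxy group, an amine or a carboxylic acid on this ring would behave like cyano or like trifluoromethyl.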